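Shortening the Hydroxycarbamoyl Chain of Compound 1

The source may report more compounds than this note shows. Statements on the series, on what has been measured and on what is new or still open speak of the compounds shown alone.

Compound 1 `Cc1ccc(-c2cc(C(=O)NCCCCCCC(=O)NO)nn2-c2ccc(S(N)(=O)=O)cc2)cc1` was tested in a functional assay on A549 cells (Homo sapiens) for inhibition, read by MTT assay, with a stated time of 72 h; a lower number here means a stronger inhibitor, a higher number a weaker inhibitor. In this assay compound 1 gives > 100000 nM, which is a limit of the assay and not a number. Its standing is therefore known only as a limit: the limit of > 100000 nM in this assay, at which 1 of the 2 values shown sits. Compound 2 `COC(=O)Cc1c(C)n(Cc2ccc(-c3cn(CCCCCCCC(=O)NO)nn3)cc2)c2ccc(OC)cc12`, which has a different core, gives a measured 4430 nM in this assay.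

The next compound keeps the core of compound 1 and alters only the chain. Compound 3 `Cc1ccc(-c2cc(C(=O)NCCCCCC(=O)NO)nn2-c2ccc(S(N)(=O)=O)cc2)cc1` has hydroxycarbamoyl in place of (hydroxycarbamoyl)methyl on a saturated chain carbon, five bonds along the chain from an amide-type nitrogen. The same difference reads as 4-(hydroxycarbamoyl)butyl to 3-(hydroxycarbamoyl)propyl.

Going by the values given here, no measured step between closely related compounds is available to size this change. The expectation therefore rests on compound 1 alone, whose limit is > 100000 nM. In this assay, no step beyond the scatter is expected in either direction, and compound 3 may well also be reported only as a limit. The expected change is a number no higher from compound 1 to compound 3 (the limit leaves the size open). Compound 3 is estimated at 100000 nM, with an expected range from 30000 nM to 300000 nM.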

Compound 3, half-maximal inhibitory concentration: > 100000 nM
Compound 3: only a limit was reported; the forecaster's own chance of this, stated with the estimate: 65%; the middle value sits exactly at the limit.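

In this assay compound 3 gives > 100000 nM, which is a limit of the assay and not a number. Going by these compounds alone, compound 1 was also reported only as a limit, so no step from compound 1 to compound 3 can be read. The compounds shown leave open whether going from 4-(hydroxycarbamoyl)butyl to 3-(hydroxycarbamoyl)propyl changes inhibition at all: the limit of > 100000 nM in this assay, at which 2 of the 3 values shown sit.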